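A propyl group on the nitrogen of compound 2

This account rests on a few compounds, and the source may have more. Where it says the series, first, only, none or still open, it means among the compounds named here.

Among the measured compounds shown here, in a functional assay on KB cells (Homo sapiens) for inhibition, with a stated time of 72 h (on this read-out higher numbers stand for weaker inhibition and lower numbers for stronger inhibition), compound 2 `COc1cc(C(=O)c2ccc3[nH]ccc3c2)cc(OC)c1OC` gives 104 nM, the only actual number measured so far. Compound 1 `COc1cc(C(=O)n2ccc3ccccc32)cc(OC)c1OC` reads > 10000 nM, which is a limit of the assay and not a number. For the measured compounds named here, compound 2 therefore stands as the sole measured point of reference, and no step between measured compounds shows what a change at this place does.

Compound 3 `CCCn1ccc2cc(C(=O)c3cc(OC)c(OC)c(OC)c3)ccc21` has propyl in place of hydrogen on an aromatic nitrogen. Going by the values given here, with no measured precedent for this change, the expectation is only a judgement, starting from compound 2 at 104 nM: a moderate loss of inhibition, beyond the scatter, with a higher number in this assay. The expected change is a 4.8-fold higher number from compound 2 to compound 3 (0.68 log units; beyond the scatter). For compound 3 the estimated value is 500 nM, with an expected range of 120 nM to 3000 nM.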

Compound 3, half-maximal inhibitory concentration: 1900 nM
For compound 3 the middle estimate is 3.8-fold (0.58 log units) below the measured one; measured number inside the range.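

In this assay, putting propyl in place of hydrogen on the aromatic nitrogen gives an 18-fold higher number from compound 2 to compound 3 (1.26 log units; beyond the scatter), a large loss of inhibition from a single change. Among the compounds shown here, this is the first measured step at this place, and it shows that the nitrogen does not tolerate propyl without a clear cost. Even so, compound 3 keeps a measured number and does not reach the limit of the assay: the limit of > 10000 nM in this assay, at which 1 of the 3 values shown sits.

With propyl as the only group shown on this nitrogen, the compounds do not tell whether the loss grows with chain length, or whether a methyl or an ethyl group would read closer to compound 2. They also leave open how a chain ending in an amine or a carboxylic acid would read at the same place.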